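The source may report more compounds than this note shows. Statements on the series, on what has been measured and on what is new or still open speak of the compounds shown alone.

Measured in a functional assay (Homo sapiens) for antiproliferative activity; a higher number here means a weaker inhibitor of growth, a lower number a stronger inhibitor of growth:
compound 1 `Cc1cn2c(/C=N/NC(=N)N)c(-c3ccncc3)nc2s1`, 9770 nM
compound 2 `Cc1sc2nc(-c3ccncc3)c(/C=N/NC(=N)N)n2c1C`, 30200 nM

For the measured compounds named here, of these two numbers, compound 1 holds the lower one; compound 2 sits a 3.1-fold higher number from compound 1 to compound 2 (0.49 log units; beyond the scatter) away, the only measured step, and it concerns a methyl group, not the pyridinyl ring. Compound 3 `Cc1cn2c(/C=N/NC(=N)N)c(-c3cccnc3)nc2s1` differs from compound 1 by pyridin-3-yl in place of pyridin-4-yl on an aromatic carbon. Going by the values given here, no measured step bears on this change, so the expectation rests on the shared core alone. A step of a 1.2-fold higher number from compound 1 to compound 3 (0.09 log units; within the scatter) is expected, nothing beyond the scatter. The estimate for compound 3 in this assay is therefore 12000 nM, within 3000 nM to 50000 nM.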

Compound 3, concentration for 50% growth inhibition: 4790 nM
Compound 3: middle estimate off by 2.5-fold (0.40 log units), on the high side; measured number inside the range.
By their numbers in this assay, from the lowest: compound 3; then compound 1; then compound 2.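

In this assay, for the compounds shown here, the step of a 2.0-fold lower number from compound 1 to compound 3 (0.31 log units; beyond the scatter) is the first measured change to the pyridinyl ring, and it shows that the choice between pyridin-4-yl and pyridin-3-yl on this aromatic carbon is not neutral. Pyridin-3-yl is the better of the two here, though the step is modest. Nothing measured on these compounds accounts for the shift. The compounds shown leave open how pyridin-2-yl or a plain phenyl ring would fare at this position. They also leave open whether the added methyl of compound 2 would have a similar effect alongside pyridin-3-yl.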